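Series notes: aryl variation on the urea nitrogen

The source may report more compounds than this note shows. Statements on the series, on what has been measured and on what is new or still open speak of the compounds shown alone.

The series shares one core, carrying a diphenyl urea whose second aryl ring is varied. Compound 1 `CCCCCN(CCCCC)C(=O)N1CCN(C(=O)N(c2ccccc2)c2ccccc2)[C@H](C(=O)O)C1` gives 1.4 nM in an assay for inhibition of Type-2 angiotensin II receptor (Rattus norvegicus); on this read-out higher numbers stand for weaker inhibition and lower numbers for stronger inhibition. Compound 2 `CCCCCN(CCCCC)C(=O)N1CCN(C(=O)N(c2ccccc2)c2cccc(Cl)c2)[C@H](C(=O)O)C1` gives 0.4 nM in this assay, and compound 3 `CCCCCN(CCCCC)C(=O)N1CCN(C(=O)N(c2ccccc2)c2cccc(C)c2)[C@H](C(=O)O)C1` gives 0.7 nM. Compound 3 sits close to both neighbours: a 2.0-fold lower number from compound 1 to compound 3 (0.30 log units; within the scatter) and a 1.8-fold higher number from compound 2 to compound 3 (0.24 log units; within the scatter), so no order among compounds 2 and 3 can be claimed. Among the measured compounds shown here, the only step beyond the scatter is a 3.5-fold lower number from compound 1 to compound 2 (0.54 log units; beyond the scatter).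

Compound 4 `CCCCCN(CCCCC)C(=O)N1CCN(C(=O)N(c2ccccc2)c2ccc(C(=O)OCC)cc2)[C@H](C(=O)O)C1` introduces a larger change: 4-(ethoxycarbonyl)phenyl in place of 3-methylphenyl on an amide-type nitrogen. For the measured compounds named here, all measured steps concern small substituents on this same ring and none moved the number by more than a modest amount; no measured pair tests an ester of this kind, so the bearing of these steps is indirect. On that basis a step of about a 1.4-fold higher number from compound 3 to compound 4 (0.15 log units; within the scatter) is expected, with no direction beyond the scatter claimed. Compound 4 is therefore estimated at 1 nM in this assay, within a range of 0.3 nM to 4 nM.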

Compound 4, half-maximal inhibitory concentration: 35 nM
Compound 4: middle estimate off by 35-fold (1.54 log units), on the low side, and the stated range ends below it.
By their numbers in this assay, from the lowest: compounds 2, 3 and 1 (each within the scatter of the next, the first and the last beyond it); then compound 4.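

The aryl group on the amide-type nitrogen proves sensitive to change in this assay: placing ethoxycarbonyl on the unsubstituted phenyl ring gives a 25-fold higher number from compound 1 to compound 4 (1.40 log units; beyond the scatter), well beyond any step among the first three compounds. The gap is also large against the two smaller substituted rings, with a 50-fold higher number from compound 3 to compound 4 (1.70 log units; beyond the scatter) and an 88-fold higher number from compound 2 to compound 4 (1.94 log units; beyond the scatter), so tolerance of 3-chlorophenyl and 3-methylphenyl does not extend to 4-(ethoxycarbonyl)phenyl. No evidence at hand accounts for the size of these steps.

The compounds shown do not separate the effect of the ester from that of its place on the ring, as the small substituents and the ester sit at different ring positions. Open too, going by these compounds, is whether a carboxylic acid, a methoxy group or a 3-(ethoxycarbonyl)phenyl group on this nitrogen stays close to compound 1 or follows compound 4.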